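Amide variation on the shared core: three measured, one pending

The source may hold more compounds than are shown below. What is called first, only, known or untested is meant among the compounds shown, and "the series" means these compounds.

Measured so far in an assay on HEK293 cells for negative allosteric modulation of metabotropic glutamate receptor 5 (Homo sapiens), read by FLIPR, with a stated time of 1 h; a higher number here means a weaker inhibitor, a lower number a stronger inhibitor:
Compound 1 `CC(=O)N1CCc2nc(C#Cc3ccccc3)sc2C1`: compound 1 gives 90 nM.
Compound 2 `CC1CC1C(=O)N1CCc2nc(C#Cc3ccccc3)sc2C1`: compound 2 reaches only the assay limit, > 10000 nM.
Compound 3 `O=C(C1CCCO1)N1CCc2nc(C#Cc3ccccc3)sc2C1`: compound 3 likewise reaches only the assay limit, > 10000 nM.

Compound 3 therefore stands at the weak end of what has been seen, known only as a limit and not as a number; the same holds for one other value, as noted in the limit of > 10000 nM in this assay, at which 2 of the 3 values shown sit.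

Compound 4 `N#Cc1cccc(C(=O)N2CCc3nc(C#Cc4ccccc4)sc3C2)c1` differs from compound 3 at the amide: 3-cyanophenyl in place of oxolan-2-yl on a carbonyl carbon.

Going by the values given here, no measured step changes the oxolan-2-yl for an aromatic group, so the bearing steps are indirect. Replacing methyl on the carbonyl carbon by a larger ring gave an at least 110-fold higher number from compound 1 to compound 2 (2.04 log units; beyond the scatter) and an at least 110-fold higher number from compound 1 to compound 3 (2.04 log units; beyond the scatter), both beyond the scatter and both ending at the limit. Between the two ring amides, a step that the two limits leave unreadable from compound 2 to compound 3 cannot be read. Going by these compounds, two larger amides have thus both lost activity past the limit, while the aromatic 3-cyanophenyl is untested; a step from compound 3 in either direction cannot be read against a limit, and a return to the potency of compound 1 is not expected.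

For compound 4 the estimate in this assay is 4000 nM, with a range from 500 nM to 20000 nM, which as a step means an at least 2.5-fold lower number from compound 3 to compound 4 (0.39 log units; beyond the scatter), still expected to fall near or at the limit.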

Compound 4, half-maximal inhibitory concentration: > 10000 nM
Compound 4 was reported as a limit; the forecaster's own chance of this, stated with the estimate: 55%; at least 2.5-fold (0.39 log units) between middle value and limit.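

In this assay the aromatic 3-cyanophenyl on the carbonyl carbon behaves like the two non-aromatic ring groups, so the loss seen with 2-methylcyclopropyl and oxolan-2-yl now extends to an aromatic ring, with an at least 110-fold higher number from compound 1 to compound 4 (2.04 log units; beyond the scatter). Compound 4 gives > 10000 nM, which is a limit of the assay and not a number. The steps among compound 2, compound 3 and compound 4 cannot be read, so no order can be given among these three amides, and what they share is their place at the limit: the limit of > 10000 nM in this assay, at which 3 of the 4 values shown sit.

Of the groups shown on the carbonyl carbon, only methyl gives a measured number, with compound 1 at 90 nM, so it remains open how far this position tolerates anything larger, such as ethyl, unsubstituted cyclopropyl or methoxymethyl. Going by these compounds, it also remains open whether an unsubstituted phenyl would differ from 3-cyanophenyl, and whether a urea or a sulfonamide in place of the amide would restore a measurable value on the shared core.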